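The source may report more compounds than this note shows. Statements on the series, on what has been measured and on what is new or still open speak of the compounds shown alone.

The shared core of these compounds carries a side chain on a sulfur, and that chain is the only thing that changes here. Going by the values given here, in a functional assay on HT cells (Homo sapiens) for antiproliferative activity, read by fluorescence, with a stated time of 72 h (a higher number here means a weaker inhibitor of growth, a lower number a stronger inhibitor of growth), compound 1 `CC(C)c1n[nH]c2c(NCc3ccc(-c4ccccn4)cc3)nc(SCC(O)C(F)(F)F)nc12` gives 690 nM and compound 2 `CC(C)c1n[nH]c2c(NCc3ccc(-c4ccccn4)cc3)nc(SC(C)C(C)O)nc12` gives 190 nM, so compound 2 holds the lower of the two numbers so far and is the stronger inhibitor of growth.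

Compound 3 `CC(C)c1n[nH]c2c(NCc3ccc(-c4ccccn4)cc3)nc(SCCCN(C)C)nc12` has not yet been measured. It carries 3-(dimethylamino)propyl in place of 2-hydroxy-1-methylpropyl on a sulfur. The hydroxyl-bearing chain gives way to one that ends in a nitrogen, a kind of group not yet tested in this set.

Among the compounds with values here, only one measured step bears on this change: a 3.6-fold lower number from compound 1 to compound 2 (0.56 log units; beyond the scatter), which also exchanges the group on that sulfur and is modest in size. That single step shows that this position can shift the number, but it gives no direction for an amine chain. A step of similar size is therefore plausible either way, so the estimate stays close to compound 2. The expected change is small, a 1.1-fold higher number from compound 2 to compound 3 (0.02 log units; within the scatter). For compound 3 the estimated value is 200 nM, with an expected range from 60 nM to 700 nM.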

Compound 3, concentration for 50% growth inhibition: 105 nM
The estimate for compound 3 lay 1.9-fold (0.28 log units) above the measured number, and the stated range covers the measured number.
By their numbers in this assay, from the lowest: compounds 3 and 2 (each within the scatter of the next); then compound 1.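

The new result shows that a hydroxyl is not needed on this sulfur chain for a number in this range, since a chain ending in a nitrogen does just as well: in this assay there is a 1.8-fold lower number from compound 2 to compound 3 (0.26 log units; within the scatter), so 3-(dimethylamino)propyl and 2-hydroxy-1-methylpropyl cannot be told apart here. The chain of compound 1 stays clearly separate, with a 6.6-fold lower number from compound 1 to compound 3 (0.82 log units; beyond the scatter), so among these three compounds, the chain bearing three fluorines gives the weakest growth inhibition. No measurement shown explains why these chains rank as they do.

Compound 2 and compound 3 differ in both the end group and the shape of the chain, so the effect of the nitrogen cannot be separated from that of the chain itself. Still open, on these data alone, is how the number would respond to a shorter or longer chain ending in the same dimethylamino group, to a primary amine or a morpholine at the chain end, or to a carboxylic acid in that place.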